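The compounds below may be only part of what the source reports. "The series", "measured", "known", "first", "only" and "open" are said of these compounds alone.

In a functional assay on the whole organism for inhibition, with Mus musculus as the target (on this read-out higher numbers stand for an effect only at larger amounts of compound and lower numbers for an effect already at smaller amounts), compound 1 (`CN1Cc2c(N)cccc2C(c2ccc(F)cc2)C1`) gives 0.25 mg/kg and compound 2 (`CC(C)c1ccc(C2CN(C)Cc3c(N)cccc32)cc1`) gives 68 mg/kg. Compound 3 (`CCNC(=O)Nc1cccc2c1CN(C)CC2c1ccccc1`) gives 54 mg/kg, which lies within the scatter of compound 2 and far from the much lower number of compound 1. Compound 4 (`CCCCNC(=O)Nc1cccc2c1CN(C)CC2c1ccccc1`) differs from compound 3 by ethyl in place of hydrogen on a saturated chain carbon, two bonds along the chain from an amide-type nitrogen, so that ethylamino becomes butylamino. Among the compounds with values here, only one measured step bears on this, and only loosely: a 270-fold higher number from compound 1 to compound 2 (2.43 log units; beyond the scatter). That step, isopropyl in place of fluoro on an aromatic carbon, shows that a single change can move this assay a long way, but it lies elsewhere on the molecule and gives no size for a change on this chain. Its direction supports only a slight lean towards a higher number, so little beyond the scatter is expected. The expected step is a 1.3-fold higher number from compound 3 to compound 4 (0.11 log units; within the scatter). Compound 4 is estimated at 70 mg/kg, with an expected range of 22 mg/kg to 220 mg/kg.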

Compound 4, dose for half-maximal effect: 23 mg/kg
Beside the measured number, compound 4's estimate is 3.0-fold (0.48 log units) above it; low and high end bracket the measured number.
By their numbers in this assay, from the lowest: compound 1; then compound 4; then compounds 3 and 2 (each within the scatter of the next).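

Within the data shown here, until this result, no change had touched the saturated chain carbon two bonds along the chain from an amide-type nitrogen. In this assay, this position responds to substitution, with a 2.3-fold lower number from compound 3 to compound 4 (0.37 log units; beyond the scatter) as ethylamino becomes butylamino. The added ethyl therefore brings the number down rather than up, although this modest step is much smaller than a 270-fold higher number from compound 1 to compound 2 (2.43 log units; beyond the scatter), which arose at an aromatic carbon elsewhere on the molecule.

A single step cannot show whether the number would fall further with a longer chain such as hexylamino, or whether a cyclohexyl ring or a terminal amine at this position would have a similar effect. Nothing available explains the lower number for compound 4.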